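Series notes: methyl on the amine nitrogen of compound 3

This account rests on a few compounds, and the source may have more. Where it says the series, first, only, none or still open, it means among the compounds named here.

Three compounds with the shared core have numbers in an assay on CHO cells with 5-hydroxytryptamine receptor 1B (Homo sapiens) as the target; on this read-out higher numbers stand for weaker inhibition and lower numbers for stronger inhibition. Compound 1 `CN(CC1CC1)CC1(O)CCN(CCCc2c[nH]c3ccc(-n4cnnc4)cc23)CC1` gives 27 nM, compound 2 `CN(CC(C)(C)C)CC1(O)CCN(CCCc2c[nH]c3ccc(-n4cnnc4)cc23)CC1` gives 61 nM, and compound 3 `Cc1ccccc1CNCC1(O)CCN(CCCc2c[nH]c3ccc(-n4cnnc4)cc23)CC1` gives 83 nM. Compound 3 stands at the highest number of the three: the step of a 3.1-fold higher number from compound 1 to compound 3 (0.49 log units; beyond the scatter) lies beyond the scatter, whereas the step of a 1.4-fold higher number from compound 2 to compound 3 (0.13 log units; within the scatter) does not, so compound 3 and compound 2 cannot be ranked against each other.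

Compound 4 `Cc1ccccc1CN(C)CC1(O)CCN(CCCc2c[nH]c3ccc(-n4cnnc4)cc23)CC1` differs from compound 3 by methyl in place of hydrogen on an amine nitrogen, so that (2-methylbenzyl)amino becomes methyl(2-methylbenzyl)amino. Going by the values given here, no measured step adds a methyl to an amine nitrogen; the change has no direct precedent. Indirectly, compound 1 and compound 2 both carry a methyl on that nitrogen, but the steps from them to compound 3 also swap the other substituent, and only one of them, from compound 1, exceeds the scatter. A step of a 1.7-fold lower number from compound 3 to compound 4 (0.22 log units; within the scatter) is therefore expected in this assay, toward a lower number but modest. Compound 4 is estimated at 50 nM, in a range from 20 nM to 130 nM.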

Compound 4, half-maximal inhibitory concentration: 89 nM
The estimate for compound 4 lay 1.8-fold (0.25 log units) below the measured number; measured number inside the range.
By their numbers in this assay, from the lowest: compound 1; then compounds 2, 3 and 4 (each within the scatter of the next).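

In this assay, going by these compounds alone, methyl in place of hydrogen on the amine nitrogen gives the first direct reading of this change (a 1.1-fold higher number from compound 3 to compound 4 (0.03 log units; within the scatter)), and with the 2-methylbenzyl group in place the two compounds cannot be told apart. Among the compounds with a methyl on that nitrogen, 2-methylphenyl in place of tert-butyl also stays within the scatter (a 1.5-fold higher number from compound 2 to compound 4 (0.16 log units; within the scatter)), whereas 2-methylphenyl in place of cyclopropyl does not (a 3.3-fold higher number from compound 1 to compound 4 (0.52 log units; beyond the scatter)), so the cyclopropylmethyl group of compound 1 remains the only substituent here that separates from the rest. No supporting data bear on this result.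

Open, going by these compounds, is whether ethyl or acetyl on that nitrogen would behave as methyl does. Also open, on these data alone, is whether the same change from hydrogen to methyl reads alike with a plain benzyl group or with cyclopropylmethyl.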